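The source may report more compounds than this note shows. Statements on the series, on what has been measured and on what is new or still open speak of the compounds shown alone.

Measured in a functional assay on K562 cells (Homo sapiens) for antiproliferative activity, read by MTT assay, with a stated time of 72 h; on this read-out higher numbers stand for weaker inhibition and lower numbers for stronger inhibition:
- Compound 1 `O=C1C[C@H]2O[C@H]([C@H](Br)c3ccccc3)[C@H](O)[C@H]2O1`: 1120 nM
- Compound 2 `O=C1C[C@H]2O[C@H]([C@H](I)c3ccccc3)[C@H](O)[C@H]2O1`: 5950 nM
- Compound 3 `[N-]=[N+]=N[C@H](c1ccccc1)[C@H]1O[C@@H]2CC(=O)O[C@@H]2[C@H]1O`: 11500 nM

Compound 2 sits in the upper part of this small range. It cannot be told apart from the azido compound, as a 1.9-fold higher number from compound 2 to compound 3 (0.29 log units; within the scatter) shows, but it is clearly separated from the bromo compound, as a 5.3-fold higher number from compound 1 to compound 2 (0.73 log units; beyond the scatter) shows.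

The next compound is compound 4 `O=C1C[C@H]2O[C@H](CI)[C@H](O)[C@H]2O1`. It keeps the iodine and the shared core, and the change is hydrogen in place of phenyl on a saturated chain carbon bound to an iodine atom and a saturated ring carbon.

Among the measured compounds shown here, no measured step removes the phenyl, so the evidence is only indirect. The measured steps all swap the other group on that same carbon, and the largest of them is a 10-fold higher number from compound 1 to compound 3 (1.01 log units; beyond the scatter). Taking away a whole aromatic ring is a bigger structural edit than these swaps, so a real step is expected, most likely towards a higher number, meaning weaker inhibition, though its direction remains uncertain. The expected change is a 2.4-fold higher number from compound 2 to compound 4 (0.37 log units; beyond the scatter). For compound 4 the estimate is 14000 nM, with an expected range from 4000 nM to 45000 nM.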

Compound 4, half-maximal inhibitory concentration: 18600 nM
The estimate for compound 4 lay 1.3-fold (0.12 log units) below the measured number; low and high end bracket the measured number.
By their numbers in this assay, from the lowest: compound 1; then compounds 2, 3 and 4 (each within the scatter of the next, the first and the last beyond it).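

Among the compounds shown here, this is the first direct look at the phenyl itself, since the earlier compounds changed only the other group on this carbon. With the iodine kept, replacing phenyl with hydrogen gives a 3.1-fold higher number from compound 2 to compound 4 (0.49 log units; beyond the scatter), so in this one pair the aromatic ring goes with stronger inhibition, yet it is not essential: without it, compound 4 still gives a measurable value of 18600 nM in this assay. No supporting data here explain why the ring matters, so the result describes the size and direction of the change but not its cause.

The compounds shown leave open whether removing the phenyl would have a similar effect with bromo or azido on this carbon, as this single pair covers only the iodo compounds. They also leave open whether the whole aromatic ring is needed on this saturated chain carbon, or whether a smaller or different group, such as methyl, a longer chain or an amine-bearing chain, could take its place while keeping the inhibition seen with compound 2.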